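Phenoxy in place of 2-methylphenyl on the shared core

The source may hold more compounds than are shown below. What is called first, only, known or untested is meant among the compounds shown, and "the series" means these compounds.

Measured so far:
compound 1 `Clc1ccc2nc(Nc3nnc(-c4ccccc4Cl)o3)sc2c1`: 53%
compound 2 `Clc1ccc(-c2nnc(Nc3nc4ccc(Cl)cc4s3)o2)c(Cl)c1`: 80%
compound 3 `Cc1ccccc1-c1nnc(Nc2nc3ccc(Cl)cc3s2)o1`: 23.9%

In a functional assay on the whole organism (strain Wistar) for inhibition, with Rattus norvegicus as the target, read by paw edema, with stated times of 1 h and 3 h, at a dose of 70 mg/kg by the oral route (on this read-out higher numbers stand for more inhibition at the one dose given (going by the name of the read-out) and lower numbers for less inhibition), compound 3 gives 23.9%, the lowest of the three numbers. The other two stand beyond the scatter above it: a number 29.1 percentage points lower from compound 1 to compound 3 (beyond the scatter) and a number 56.1 percentage points lower from compound 2 to compound 3 (beyond the scatter). The remaining step, a number 27 percentage points higher from compound 1 to compound 2 (beyond the scatter), shows that an added chloro on the pendant ring raised the read-out.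

Compound 4 `Clc1ccc2nc(Nc3nnc(Oc4ccccc4)o3)sc2c1` differs from compound 3 by phenoxy in place of 2-methylphenyl on an aromatic carbon. Among the compounds with values here, no measured step brings in a phenoxy group, so none bears on this change directly. The nearest reference is the step from compound 1 to compound 3, where a methyl in place of a chloro on the pendant ring lowered the number; compound 4 has neither methyl nor chloro there. The expectation is therefore a step of uncertain direction, most likely a modest rise, estimated as a number 11.1 percentage points higher from compound 3 to compound 4 (beyond the scatter). For compound 4 the expected value in this assay is 35%, with a range from 15% to 60%.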

Compound 4, a percentage reported as inhibition, in the whole organism at one dose (the size of the read-out at that dose, not a potency): 74.2%
Beside the measured number, compound 4's estimate is 39.2 percentage points below it; the whole stated range lies below it.
By their numbers in this assay, from the lowest: compound 3; then compound 1; then compounds 4 and 2 (each within the scatter of the next).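

In this assay this position on the five-membered aromatic ring does not need an aryl carbon directly attached: the swap to phenoxy gives a number 50.3 percentage points higher from compound 3 to compound 4 (beyond the scatter) and also a number 21.2 percentage points higher from compound 1 to compound 4 (beyond the scatter) when set against the 2-chlorophenyl. Before this result only the 2,4-dichlorophenyl reached the top of the series, yet phenoxy, which has no chloro on its ring, gives a number 5.8 percentage points lower from compound 2 to compound 4 (within the scatter) and so reads level with it in this assay. Nothing available accounts for the size of the change from 2-methylphenyl to phenoxy.

The compounds shown do not separate the effect of the oxygen link from that of losing the methyl. Also open, as far as these compounds go, is whether an amine link in place of that oxygen, or a longer chain such as benzyloxy, would hold the number at this position.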